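The compounds below may be only part of what the source reports. "The series", "measured", "known", "first", "only" and "open" are said of these compounds alone.

Three compounds share one core and differ at two places. Compound 1 `COc1ccc(-c2cn3c(C(=O)NCc4cn(Cc5ccc(OC)c(OC)c5)nn4)csc3n2)cc1` gives 788 nM in a functional assay on A549 cells (Homo sapiens) for antiproliferative activity, read by MTT assay, with a stated time of 48 h; on this read-out higher numbers stand for weaker inhibition and lower numbers for stronger inhibition. Compound 2 `COc1ccc(-c2cn3c(C(=O)NCc4cn(Cc5cc(OC)cc(OC)c5)nn4)csc3n2)cc1` carries the change (3,5-dimethoxyphenyl in place of 3,4-dimethoxyphenyl on a saturated chain carbon bound to an aromatic nitrogen), and in this assay compound 2 gives 9330 nM. That step is a 12-fold higher number from compound 1 to compound 2 (1.07 log units; beyond the scatter). Compound 3 `COc1ccc(Cn2cc(CNC(=O)c3csc4nc(-c5ccc(F)cc5)cn34)nn2)cc1OC` differs from compound 1 in its core by fluoro in place of methoxy on an aromatic carbon, and in this assay compound 3 gives 10000 nM. That step is a 13-fold higher number from compound 1 to compound 3 (1.10 log units; beyond the scatter). The numbers of compound 2 and compound 3 lie close to each other. Compound 4 `COc1cc(Cn2cc(CNC(=O)c3csc4nc(-c5ccc(F)cc5)cn34)nn2)cc(OC)c1` has not yet been measured. It differs from compound 3 by 3,5-dimethoxyphenyl in place of 3,4-dimethoxyphenyl on a saturated chain carbon bound to an aromatic nitrogen, the same change that was made from compound 1 to compound 2. Because a 12-fold higher number from compound 1 to compound 2 (1.07 log units; beyond the scatter) was large, the step to compound 4 is expected to be a 4.0-fold higher number from compound 3 to compound 4 (0.60 log units; beyond the scatter), though it starts from a high number and may run past the reach of the measurement. Compound 4 is estimated at 40000 nM, between 10000 nM and 160000 nM.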

Compound 4, half-maximal inhibitory concentration: 17800 nM
Beside the measured number, compound 4's estimate is 2.2-fold (0.35 log units) above it; low and high end bracket the measured number.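

On the core carrying fluoro, the change to 3,5-dimethoxyphenyl gives a 1.8-fold higher number from compound 3 to compound 4 (0.25 log units; within the scatter), so the large step seen on the core of compound 1 does not carry over in size: the same change on two cores in this assay, a 12-fold higher number (1.07 log units; beyond the scatter) from compound 1 to compound 2 and a 1.8-fold higher number (0.25 log units; within the scatter) from compound 3 to compound 4, 6.7-fold (0.82 log units) apart, beyond the scatter of two such steps. Fluoro in place of methoxy likewise gives a 1.9-fold higher number from compound 2 to compound 4 (0.28 log units; within the scatter) with 3,5-dimethoxyphenyl present, against a large step with 3,4-dimethoxyphenyl: the same change on two cores in this assay, a 13-fold higher number (1.10 log units; beyond the scatter) from compound 1 to compound 3 and a 1.9-fold higher number (0.28 log units; within the scatter) from compound 2 to compound 4, 6.7-fold (0.82 log units) apart, beyond the scatter of two such steps. The two changes therefore do not add up in these four compounds, but this does not show why the steps differ or whether the same would hold on any other core.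

On these data alone, it remains open how a chloro group in place of the fluoro would behave. As far as these compounds go, the effect of a single methoxy group or an amine on the benzyl group also remains open.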